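This account rests on a few compounds, and the source may have more. Where it says the series, first, only, none or still open, it means among the compounds named here.

Measured compounds in a functional assay on KOPN-8 cells (Homo sapiens) for antiproliferative activity, with a stated time of 72 h; a lower number here means that less compound is needed, a higher number that more compound is needed for the effect:

compound 1, `COc1ccc(-c2cc(=O)c3c(OC)cc(OC)cc3n2S(=O)(=O)c2ccc([N+](=O)[O-])cc2)cc1` — compound 1 gives 17300 nM
compound 2, `COc1ccc(-c2cc(=O)c3c(OC)cc(OC)cc3n2S(=O)(=O)c2ccc(F)cc2)cc1` — compound 2 gives > 65500 nM
compound 3, `COc1cc(OC)c2c(=O)cc(C(=O)Nc3ccc(Oc4ccc([N+](=O)[O-])cc4)cc3)[nH]c2c1` — compound 3 gives 20500 nM

The value of compound 2 is a limit of the assay and not a number; (the limit of > 65500 nM in this assay, at which 1 of the 3 values shown sits).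

Compound 1 and compound 2 differ in one place, (fluoro in place of nitro on an aromatic carbon). This change gives an at least 3.7-fold higher number from compound 1 to compound 2 (0.57 log units; beyond the scatter) in this assay. Compound 1 and compound 3 do not share a single counted difference; how the two cores differ is not broken down here. Within the scatter, compound 3 and compound 1 stand side by side.

Compound 4, `COc1cc(OC)c2c(=O)cc(C(=O)Nc3ccc(Oc4ccc(F)cc4)cc3)[nH]c2c1`, has not yet been measured. It differs from compound 3 by fluoro in place of nitro on an aromatic carbon. The place of the change is the same as between compound 1 and compound 2, and the wider reading also gives 4-nitrophenoxy to 4-fluorophenoxy, so the change is of the same kind.

For compound 4 in this assay a step of a 3.4-fold higher number from compound 3 to compound 4 (0.53 log units; beyond the scatter) from compound 3 is expected, resting on the single earlier occurrence of this change, where compound 1 to compound 2 gave an at least 3.7-fold higher number from compound 1 to compound 2 (0.57 log units; beyond the scatter). Compound 3 starts at 20500 nM. A step of that size would carry compound 4 towards (the limit of > 65500 nM in this assay, at which 1 of the 3 values shown sits), so a limit rather than a number is a real possibility. The estimate for compound 4 is 70000 nM, with a range from 30000 nM to 160000 nM.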

Compound 4, half-maximal effective concentration: > 50000 nM
Compound 4: no number, only a limit; the forecaster's own chance of this, stated with the estimate: 55%; the middle value lies beyond the limit too.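

In this assay, fluoro in place of nitro on the aromatic carbon of the 4-nitrophenoxy group gives an at least 2.4-fold higher number from compound 3 to compound 4 (0.38 log units; beyond the scatter). The change therefore moves the number the same way on both cores, with both steps printed as beyond the scatter, and on both cores the fluoro compound reaches a limit of the assay rather than a number: the same change on two cores in this assay, an at least 3.7-fold higher number (0.57 log units; beyond the scatter) from compound 1 to compound 2 and an at least 2.4-fold higher number (0.38 log units; beyond the scatter) from compound 3 to compound 4; the limit leaves it open whether they differ This shows that the direction carried over from one core to the other in these two pairs, but it does not give the full size of either step, does not show that the two sizes match, and says nothing about a third core or about why the number rises.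

The compounds shown cover only nitro and fluoro at this place on the two cores, so it stays open how an amine, a nitrile or a carboxylic acid there would read in this assay. Going by these compounds, with compound 1 at 17300 nM and compound 3 at 20500 nM, it also stays open whether any group at this place gives a lower number than nitro does on these cores.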